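The compounds below may be only part of what the source reports. "The series", "measured", "known", "first", "only" and "open" are said of these compounds alone.

Three compounds have been measured in a functional assay on the whole organism (strain Sprague-Dawley) for inhibition, with Rattus norvegicus as the target, with a stated time of 10 min; on this read-out higher numbers stand for an effect only at larger amounts of compound and lower numbers for an effect already at smaller amounts:

Compound 1 `CCOc1ccccc1-c1ncc(C(=O)O)c(=O)[nH]1`: compound 1 gives 0.5 mg/kg.
Compound 2 `CCCOc1ccccc1-c1ncc(C(=O)O)c(=O)[nH]1`: compound 2 gives 0.9 mg/kg.
Compound 3 `CCOC(=O)c1cnc(-c2cc(OC)ccc2OCC)[nH]c1=O`: compound 3 gives 0.3 mg/kg.

Compounds 1 and 2 share a core and differ in one place: methyl in place of hydrogen on a saturated chain carbon, two bonds along the chain from an oxygen on an aromatic ring. This change gave a 1.8-fold higher number from compound 1 to compound 2 (0.26 log units; within the scatter), so the two compounds cannot be told apart on this read-out.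

Compound 4 `CCCOc1ccc(OC)cc1-c1ncc(C(=O)OCC)c(=O)[nH]1` has not yet been measured. It stands to compound 3 as compound 2 stands to compound 1, namely (methyl in place of hydrogen on a saturated chain carbon, two bonds along the chain from an oxygen on an aromatic ring). The place of the change is described in the same words for both pairs, so it is the same change, made on a different core. Compound 3 and compound 1 differ in more than one place, and the difference between the two cores is not broken down here.

Among the measured compounds shown here, the only guide to what compound 4 will do is the earlier step, which lay within the scatter of this assay. On that basis compound 4 is expected to show a step of about a 1.7-fold higher number from compound 3 to compound 4 (0.22 log units; within the scatter), because the same change from compound 1 to compound 2 gave a 1.8-fold higher number from compound 1 to compound 2 (0.26 log units; within the scatter). Whether a change carries over from one core to another is not known from these compounds alone, so the range is kept wide. Compound 4 is estimated at 0.5 mg/kg, with a likely range from 0.2 mg/kg to 1.3 mg/kg.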

Compound 4, dose for 50% inhibition: 0.7 mg/kg
The estimate for compound 4 lay 1.4-fold (0.15 log units) below the measured number; measured number inside the range.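

In this assay the change from ethoxy to propoxy on the core of compound 3 gave a 2.3-fold higher number from compound 3 to compound 4 (0.37 log units; beyond the scatter), and taken alone this step can be read as a real, though modest, loss of effect at a given dose. Set beside the same change on the other core, it does not stand apart, so as far as this read-out can tell the change carried over from one core to the other: the same change on two cores in this assay, a 1.8-fold higher number (0.26 log units; within the scatter) from compound 1 to compound 2 and a 2.3-fold higher number (0.37 log units; beyond the scatter) from compound 3 to compound 4, 1.3-fold (0.11 log units) apart, within the scatter of two such steps. This does not show that the second core responds more strongly than the first, and two pairs cannot show that the change would behave alike on a third core or explain why it behaves as it does.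

The compounds shown stop at propoxy, so it remains open how a longer chain such as butoxy, or a chain carrying an amine, would fare on either core. Compound 1 and compound 3 also differ in more than one place, which leaves the separate contributions of the ethyl ester and the methoxy group unresolved.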